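Urea Analogue of a Chlorinated Amide: Expected Growth Inhibition

This account rests on a few compounds, and the source may have more. Where it says the series, first, only, none or still open, it means among the compounds named here.

Compound 1 `COc1cc(-c2nn(-c3cccc(NC(=O)Nc4cccc(C(F)(F)F)c4)c3)cc2-c2ccncc2)ccc1Cl` gives 2140 nM in a functional assay on MDA-MB-435 cells (Homo sapiens) for inhibition, read by sulforhodamine B assay, with a stated time of 48 h; on this read-out higher numbers stand for weaker inhibition of growth and lower numbers for stronger inhibition of growth.
Compound 2 `COc1cc(-c2nn(-c3cccc(NC(=O)c4ccc(Cl)c(C(F)(F)F)c4)c3)cc2-c2ccncc2)ccc1Cl` gives 1740 nM in this assay.

Of the two numbers, that of compound 2 is the smaller, yet a 1.2-fold lower number from compound 1 to compound 2 (0.09 log units; within the scatter) lies within the scatter, so the two compounds are not told apart. Compound 3 `COc1cc(-c2nn(-c3cccc(NC(=O)Nc4ccc(Cl)c(C(F)(F)F)c4)c3)cc2-c2ccncc2)ccc1Cl` differs from compound 2 by (4-chloro-3-(trifluoromethyl)phenyl)amino in place of 4-chloro-3-(trifluoromethyl)phenyl on a carbonyl carbon. Among the measured compounds shown here, the one measured step bearing on this is a 1.2-fold lower number from compound 1 to compound 2 (0.09 log units; within the scatter), which also exchanged an amide for a urea, though together with a change in the aryl group, and it was small. A small movement, or none beyond the scatter, is therefore expected for a 1.1-fold lower number from compound 2 to compound 3 (0.04 log units; within the scatter). Compound 3 is estimated at 1600 nM, within 600 nM to 4200 nM.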

Compound 3, concentration for total growth inhibition: 1690 nM
The estimate for compound 3 lay 1.1-fold (0.02 log units) below the measured number, and the stated range covers the measured number.
By their numbers in this assay, from the lowest: compounds 3, 2 and 1 (each within the scatter of the next).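

In this assay the change from amide to urea now stands alone, with the aryl group held constant: a 1.0-fold lower number from compound 2 to compound 3 (0.01 log units; within the scatter) shows that the extra amide-type nitrogen on the carbonyl carbon does not separate the two compounds. Chloro in place of hydrogen on an aromatic carbon is also seen alone for the first time, and a 1.3-fold lower number from compound 1 to compound 3 (0.10 log units; within the scatter) does not separate that pair either. Nothing at hand accounts for these two steps. The compounds shown leave open whether a fluoro or a nitrile in place of that chloro, or a methylene in place of the urea nitrogen, would move the number beyond the scatter.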